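A few compounds are considered here, and "the series" means these few. Any claim that something is new, unique, unknown or untested is made for them only; others in the source may bear on it.

Measured so far in an assay on CHO cells for displacement of a labelled ligand from 5-hydroxytryptamine receptor 1B (Homo sapiens); a lower number here means a stronger inhibitor, a higher number a weaker inhibitor:
compound 1 `OC[C@H](NC1CCN(CCCc2c[nH]c3ccc(-n4ccnc4)cc23)CC1)c1ccccc1` gives 100 nM
compound 2 `c1ccc2c(c1)CCC2NC1CCN(CCCc2c[nH]c3ccc(-n4cnnc4)cc23)CC1` gives 280 nM
compound 3 `CC(=O)Nc1ccc(CNC2CCN(CCCc3c[nH]c4ccc(-n5cnnc5)cc34)CC2)cc1` gives 45 nM

Compound 2 stands highest of the three numbers in this assay; compound 1 is the nearest, compound 3 the furthest, with a 6.2-fold lower number from compound 2 to compound 3 (0.79 log units; beyond the scatter).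

Compound 4 `c1ccc(NCC2CCN(CCCc3c[nH]c4ccc(-n5cnnc5)cc34)CC2)nc1` is the next step from compound 2: ((pyridin-2-yl)amino)methyl in place of (2,3-dihydro-1H-inden-1-yl)amino on a saturated ring carbon. For the measured compounds named here, the only measured step that bears on it is a 6.2-fold lower number from compound 2 to compound 3 (0.79 log units; beyond the scatter), where the same 2,3-dihydro-1H-inden-1-yl group was likewise removed in favour of a group carrying an aromatic ring on a one-carbon link. Going by the values given here, a lower number of modest size is therefore expected, a 3.5-fold lower number from compound 2 to compound 4 (0.54 log units; beyond the scatter), though compound 3 is the only precedent and the pyridin-2-yl amine is untested here. Compound 4 is estimated at 80 nM, range 30 nM to 250 nM.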

Compound 4, half-maximal inhibitory concentration: 3.3 nM
Beside the measured number, compound 4's estimate is 24-fold (1.38 log units) above it, and the stated range ends above it.
By their numbers in this assay, from the lowest: compound 4; then compound 3; then compound 1; then compound 2.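

In this assay the swap gives an 85-fold lower number from compound 2 to compound 4 (1.93 log units; beyond the scatter) and so shows that the group on this saturated ring carbon can shift the number strongly. The entering group has fewer heavy atoms and a single six-membered aromatic ring with 1 hetero atom, so the five-membered non-aromatic ring of the leaving group is not needed for a low number here. Nothing available accounts for the size of this step.

The change alters the ring and the link together, so their shares remain unseparated. A (phenylamino)methyl group or a (pyridin-2-yl)amino group without the methyl link would separate them.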